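Pyridine amide swap in the cytotoxicity series

A few compounds are considered here, and "the series" means these few. Any claim that something is new, unique, unknown or untested is made for them only; others in the source may bear on it.

- compound 1 `CC(NC(=O)C1CCN(C(=O)c2cc3ccccc3n2Cc2ccc(Cl)cc2)CC1)c1ccncc1`: 90100 nM
- compound 2 `O=C(NCCCc1ccncc1)C1CCN(C(=O)c2cc3ccccc3n2Cc2ccc(Cl)cc2)CC1`: 71500 nM

In an ADME assay on BE(2)-C cells (Homo sapiens) for cytotoxicity, read by MTT assay, with a stated time of 20 h (on this read-out lower numbers stand for higher toxicity in this test and higher numbers for lower toxicity in this test), within the scatter of compound 1, compound 2 stands at 71500 nM. The next analogue is compound 3 `O=C(c1cc2ccccc2n1Cc1ccc(Cl)cc1)N1CCC(C(=O)N2CCC[C@H]2CO)CC1`, which has not yet been measured. The change is 2-(hydroxymethyl)pyrrolidin-1-yl in place of (3-(pyridin-4-yl)propyl)amino on a carbonyl carbon. Among the compounds with values here, only one measured step bears on it: a 1.3-fold lower number from compound 1 to compound 2 (0.10 log units; within the scatter). That step swaps one pyridin-4-yl side chain for another on an amide-type nitrogen and stays small. Within the data shown here, no measured compound lacks the pyridin-4-yl group, so the data offer no direct precedent for this replacement, and the estimate stays wide. Nothing measured points to a shift in either direction, so no change beyond the scatter is expected, and the expected step is a 1.2-fold higher number from compound 2 to compound 3 (0.08 log units; within the scatter). Compound 3 is estimated at 85000 nM, with an expected range of 30000 nM to 220000 nM.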

Compound 3, half-maximal cytotoxic concentration: 98900 nM
The estimate for compound 3 lay 1.2-fold (0.07 log units) below the measured number, and the stated range covers the measured number.
By their numbers in this assay, from the lowest: compounds 2, 1 and 3 (each within the scatter of the next).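

In this assay, 2-(hydroxymethyl)pyrrolidin-1-yl in place of (3-(pyridin-4-yl)propyl)amino on the carbonyl carbon gives a 1.4-fold higher number from compound 2 to compound 3 (0.14 log units; within the scatter), and in place of (1-(pyridin-4-yl)ethyl)amino it gives a 1.1-fold higher number from compound 1 to compound 3 (0.04 log units; within the scatter). The earlier pair varied only the chain carrying the pyridin-4-yl group, whereas these steps show that, among the three compounds, the read-out stays within the scatter when that aromatic ring is replaced by a five-membered non-aromatic ring carrying a defined stereocentre. No available evidence accounts for this result.

From the compounds shown here alone, whether a charged group at this carbonyl carbon, such as a primary amine or a carboxylic acid, would shift the number beyond the scatter remains open. Going by these compounds, the opposite stereoisomer of the 2-(hydroxymethyl)pyrrolidin-1-yl group also remains open.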